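Same substituent, a different core, in a cytotoxicity assay

The source may hold more compounds than are shown below. What is called first, only, known or untested is meant among the compounds shown, and "the series" means these compounds.

Of the compounds shown here, three have been measured in an ADME assay on THP-1 cells (Homo sapiens) for cytotoxicity, read by flow cytometry, with a stated time of 72 h; a higher number here means a weaker inhibitor, a lower number a stronger inhibitor. Compound 1, with the structure `N/C(=N\O)c1ccc(S(=O)(=O)C2=C(c3ccccc3)OC(c3ccccc3)(c3ccccc3)C2)cc1`, gives 37900 nM. Compound 3, with the structure `N/C(=N\O)c1ccc(Nc2ccc(C3=C(S(=O)(=O)c4ccc(/C(N)=N/O)cc4)CC(c4ccccc4)(c4ccccc4)O3)cc2)cc1`, gives 48900 nM. The two differ in one place: a group of 11 heavy atoms (7 carbon, 3 nitrogen, 1 oxygen; one six-membered aromatic ring of carbon only) in place of a hydrogen atom, on an aromatic carbon. That change made a step of a 1.3-fold higher number from compound 1 to compound 3 (0.11 log units; within the scatter).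

Compound 2, with the structure `CC1(Cc2ccccc2)CC(S(=O)(=O)c2ccccc2)=C(c2ccc(/C(N)=N/O)cc2)O1`, gives 94600 nM in this assay. Its core is not the core of compound 1, and the difference between the two cores is not broken down here. The number for compound 2 is within the scatter of that for compound 3 and beyond the scatter of that for compound 1.

Compound 4, with the structure `CC1(Cc2ccccc2)CC(S(=O)(=O)c2ccc(Nc3ccc(/C(N)=N/O)cc3)cc2)=C(c2ccc(/C(N)=N/O)cc2)O1`, has not yet been measured. It differs from compound 2 in the same place and by the same group as compound 3 differs from compound 1: a group of 11 heavy atoms (7 carbon, 3 nitrogen, 1 oxygen; one six-membered aromatic ring of carbon only) in place of a hydrogen atom, on an aromatic carbon. Among the compounds shown the change occurs two times in all.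

Within the data shown here, the expectation for compound 4 rests on the one measured instance of this change, because the step of a 1.3-fold higher number from compound 1 to compound 3 (0.11 log units; within the scatter) lay within the scatter. Accordingly the step from compound 2 to compound 4 is expected to be about a 1.3-fold higher number from compound 2 to compound 4 (0.10 log units; within the scatter) in this assay. Compound 4 is therefore estimated at 120000 nM, with the range 60000 nM to 250000 nM.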

Compound 4, half-maximal inhibitory concentration: 47600 nM
Compound 4: middle estimate off by 2.5-fold (0.40 log units), on the high side, outside the stated range (below it).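

On the core of compound 2, the group of 11 heavy atoms in place of a hydrogen atom gave a 2.0-fold lower number from compound 2 to compound 4 (0.30 log units; within the scatter) in this assay. Set beside the earlier step, this result gives no sign that the two cores respond differently: the same change on two cores in this assay, a 1.3-fold higher number (0.11 log units; within the scatter) from compound 1 to compound 3 and a 2.0-fold lower number (0.30 log units; within the scatter) from compound 2 to compound 4, 2.6-fold (0.41 log units) apart, within the scatter of two such steps. Within this pair of cores, the change therefore carries over in the limited sense that neither step lies beyond the scatter, but two pairs cannot show that the step is the same on both cores, nor that it would stay within the scatter on any other core.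

The compounds shown leave open whether a third core would give a step of similar size. They also leave open whether another group on the same aromatic carbon, such as an amine, a carboxylic acid or a longer chain, would give a step beyond the scatter.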